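Fluoro to hydroxymethyl with a half-life at the limit

This account rests on a few compounds, and the source may have more. Where it says the series, first, only, none or still open, it means among the compounds named here.

Measured in an ADME assay for pharmacokinetics, read by LC-MS, in phosphate buffer, with a stated time of 120 min, at pH 7.4, tested at 1 uM, in the presence of a further agent that is not named here (a higher number here means that the compound lasts longer, a lower number that the compound disappears faster), all three values being limits:
Compound 1 `C=C(Cc1ccccc1)C(=O)Nc1ccccc1`: > 8.53 h (limit)
Compound 2 `O=C(/C=C/CF)Nc1ccccc1`: > 8.53 h (limit)
Compound 3 `C=C(F)C(=O)Nc1ccccc1`: > 8.53 h (limit)

Compound 3 stands at > 8.53 h in this assay and that value is a limit, not a number. It shares this place with the other two compounds, as the limit of > 8.53 h in this assay, at which 3 of the 3 values shown sit, makes plain.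

Compound 4 `C=C(CO)C(=O)Nc1ccccc1` has not yet been measured. Its difference from compound 3 is hydroxymethyl in place of fluoro on a double-bonded chain carbon bound to a carbonyl carbon and it amounts to hydroxymethyl in place of fluoro on a double-bonded chain carbon bound to a carbonyl carbon. Cut one bond further out, the same difference reads 1-fluoroethenyl to 1-(hydroxymethyl)ethenyl.

Going by the values given here, the one measured step that bears on this also alters the group on a carbonyl carbon, with 1-fluoroethenyl in place of 3-fluoroprop-1-en-1-yl. Among the compounds with values here, it is a step that the two limits leave unreadable from compound 2 to compound 3 and it offers no size to carry over, so no measured step points in a direction.

The expectation rests on compound 3, whose > 8.53 h remains a limit, and no change beyond the scatter is foreseen. The expected step is a step that the limit leaves unreadable from compound 3 to compound 4 and it is only an estimate. For compound 4 the estimated half-life in this assay is 9 h (expected range 4 h to 20 h).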

Compound 4, half-life: > 8.53 h
Compound 4: only a limit was reported (the forecaster's own chance of this, stated with the estimate: 65%); the middle value is on the limit's open side.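

In this assay compound 4 gives > 8.53 h as a limit, not a number. Going by these compounds alone, no step between compound 4 and compound 1, compound 2 or compound 3 can be read, since all four compounds stand at the same limit: the limit of > 8.53 h in this assay, at which 4 of the 4 values shown sit. The compounds shown leave open how long any of them actually lasts, and whether hydroxymethyl in place of fluoro changes the half-life at all.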